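A few compounds are considered here, and "the series" means these few. Any claim that something is new, unique, unknown or untested is made for them only; others in the source may bear on it.

Working notes on the series in an ADME assay on MT4 cells (Homo sapiens) for cytotoxicity; a higher number here means that more compound is tolerated, a lower number that less compound is tolerated.

Compound 1 `Cc1cc(C)cc(Cn2c(=S)[nH]c3ccccc32)c1` gives 5740 nM in this assay. Compound 2 `Cc1cc(C)cc(Cn2c(=S)[nH]c3ccc(Cl)cc32)c1` carries the change chloro in place of hydrogen on an aromatic carbon on the core of compound 1; in this assay compound 2 gives 305 nM, so the step is a 19-fold lower number from compound 1 to compound 2 (1.27 log units; beyond the scatter). No measured property of the chloro group is shown for this series, and no cause for that step is offered.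

Compound 3 `Cc1cc(C)cc(Cn2c(SCC(=O)Nc3ccccc3Br)nc3ccccc32)c1` has a core that differs from the core of compound 1 in more than one place; the difference between the two cores is not broken down here. In this assay, among the measured compounds shown here, compound 3 gives only >= 143000 nM, which is a limit of the assay and not a number, and it is the one value that sits at the limit of >= 143000 nM in this assay, at which 1 of the 3 values shown sits.

Compound 4 `Cc1cc(C)cc(Cn2c(SCC(=O)Nc3ccccc3Br)nc3ccc(Cl)cc32)c1` differs from compound 3 by chloro in place of hydrogen on an aromatic carbon, the same change as that from compound 1 to compound 2, with the same surroundings at the place of the change; the change occurs in two pairs among the compounds shown. A step of comparable direction is expected from compound 3 to compound 4, an at least 4.7-fold lower number from compound 3 to compound 4 (0.67 log units; beyond the scatter), resting on the measured step of a 19-fold lower number from compound 1 to compound 2 (1.27 log units; beyond the scatter). Since the starting value of compound 3 is a limit, the expected step is widely uncertain. For compound 4 the estimate in this assay is 30000 nM, with an expected range from 5000 nM to 150000 nM, and a fair chance that the assay again reports only a limit.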

Compound 4, half-maximal cytotoxic concentration: 174000 nM
Estimate against measurement, compound 4: 5.8-fold (0.76 log units) below, and the stated range ends below it.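

The step from compound 3 to compound 4 in this assay cannot be read, since the value of compound 3 is a limit of the assay and not a number: the limit of >= 143000 nM in this assay, at which 1 of the 4 values shown sits.

The compounds shown leave open whether a 19-fold lower number from compound 1 to compound 2 (1.27 log units; beyond the scatter) has a counterpart of similar direction and size on the core of compound 3.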